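Adding a phenyl to the shared core of compound 2

A few compounds are considered here, and "the series" means these few. Any claim that something is new, unique, unknown or untested is made for them only; others in the source may bear on it.

Measured compounds:
compound 1 `O=C(Nc1nccn2cc(-c3ccccc3)nc12)c1ccccc1` gives 18%
compound 2 `O=C(Nc1nccn2cc(-c3ccccc3)nc12)c1cccnc1` gives 24%
compound 3 `O=C(Nc1ccccc1)Nc1nccn2cc(-c3ccccc3)nc12` gives 1%

The three compounds were tested in an assay on cells for displacement of a labelled ligand from adenosine receptor A1 (Homo sapiens), read by scintillation counting, with a stated time of 120 min, tested at 1 uM; on this read-out higher numbers stand for more inhibition at the one concentration tested (going by the name of the read-out) and lower numbers for less inhibition. Compound 2 stands highest on these numbers, but its gap to compound 1, a number 6 percentage points higher from compound 1 to compound 2 (within the scatter), is within the scatter, so the two cannot be told apart. Compound 3 sits clearly lower: a number 17 percentage points lower from compound 1 to compound 3 (beyond the scatter) and a number 23 percentage points lower from compound 2 to compound 3 (beyond the scatter) are both beyond the scatter.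

Compound 4 `O=C(Nc1nc(-c2ccccc2)cn2cc(-c3ccccc3)nc12)c1cccnc1` is not yet measured. It differs from compound 2 in one place: phenyl in place of hydrogen on an aromatic carbon. Going by the values given here, all three measured steps change the group on the carbonyl carbon; none of them changes the core itself, so no measured step bears directly on this change. Among the compounds with values here, the only guidance is that compound 2 in this assay gives 24%, and a phenyl on the core adds no donor or acceptor.

Within the data shown here, with no relevant step to lean on, the expectation for compound 4 is simply close to compound 2, a step of a number 1 percentage points higher from compound 2 to compound 4 (within the scatter) that is not expected to go beyond the scatter, with a wide range on either side. Compound 4 is therefore estimated at 25%, between 5% and 50%.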

Compound 4, a percentage reported as inhibition, at one concentration (the size of the read-out at that concentration, not a potency): 11%
Compound 4: the middle estimate sits 14 percentage points above what was measured; the measured number falls inside the stated range.
By their numbers in this assay, from the lowest: compounds 3, 4, 1 and 2 (each within the scatter of the next, the first and the last beyond it).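

Placing a phenyl on this aromatic carbon of the shared core, next to the ring nitrogen, gives a number 13 percentage points lower from compound 2 to compound 4 (beyond the scatter) in this assay and so lowers the number rather than leaving it unchanged. Going by these compounds alone, the earlier steps changed only the group on the carbonyl carbon, so this is the first sign that the core itself is sensitive to substitution, at least at this position and with this group, though the read-out reflects a single concentration and is not a potency. Nothing shown here gives a reason for the lower number.

Going by these compounds, it remains open whether any group on this carbon would lower the number or whether this is specific to phenyl, which a methyl group, a methoxy group or an amine at the same place could help to settle. On these data alone, it is also open whether the same phenyl would have a similar effect with the benzoyl group of compound 1 or the anilino carbonyl group of compound 3 in place of the pyridin-3-yl carbonyl group of compound 2.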